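A few compounds are considered here, and "the series" means these few. Any claim that something is new, unique, unknown or untested is made for them only; others in the source may bear on it.

Three compounds share one core and differ only in a group on the aromatic ring of the ketone side. Compound 1 `O=C(/C=C/c1ccc2c(c1)B(O)OC2)c1ccccc1` carries hydrogen there, and in a functional assay on SK-OV-3 cells (Homo sapiens) for cytotoxicity, read by MTT assay, with a stated time of 48 h (on this read-out higher numbers stand for weaker inhibition and lower numbers for stronger inhibition), compound 1 gives 3400 nM. Compound 2 `O=C(/C=C/c1ccc2c(c1)B(O)OC2)c1ccc(Cl)cc1` carries chloro and in this assay compound 2 gives 3700 nM, while compound 3 `CSc1ccc(C(=O)/C=C/c2ccc3c(c2)B(O)OC3)cc1` carries methylsulfanyl and in this assay compound 3 gives 4100 nM. Neither replacement moved the number beyond the scatter: the step of a 1.1-fold higher number from compound 1 to compound 2 (0.04 log units; within the scatter) and the step of a 1.2-fold higher number from compound 1 to compound 3 (0.08 log units; within the scatter) are both small, and likewise a 1.1-fold higher number from compound 2 to compound 3 (0.04 log units; within the scatter). Compound 1 therefore stands together with compound 2 and compound 3, none of the three separable from the others.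

Compound 4 `O=C(/C=C/c1ccc2c(c1)B(O)OC2)c1ccc(C(F)(F)F)cc1` differs from compound 1 by trifluoromethyl in place of hydrogen on an aromatic carbon. The two measured steps from compound 1 bear directly on this change, since each places a group at the same position, and each stayed within the scatter. The expectation is thus a step of a 1.1-fold higher number from compound 1 to compound 4 (0.05 log units; within the scatter), no larger than the scatter, in this assay. Compound 4 is estimated at 3800 nM, with a range from 1900 nM to 7600 nM.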

Compound 4, half-maximal inhibitory concentration: 3700 nM
The estimate for compound 4 lay 1.0-fold (0.01 log units) above the measured number; the range from low to high includes it.
By their numbers in this assay, from the lowest: compounds 1, 2, 4 and 3 (each within the scatter of the next).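

In this assay, trifluoromethyl on this aromatic carbon, para to a large group, is a third replacement of hydrogen that stays within the scatter, with a 1.1-fold higher number from compound 1 to compound 4 (0.04 log units; within the scatter). It also cannot be separated from either of the other two groups, with no change at the digits printed from compound 2 to compound 4 (within the scatter) and a 1.1-fold lower number from compound 3 to compound 4 (0.04 log units; within the scatter), so the four compounds form a single set with no order among them, and the change of group at this place has shown no effect on the number so far. No data are at hand to explain why the number stays the same across these groups.

On these data alone, whether an amine, a carboxylic acid or a longer chain at this place would also stay within the scatter remains open. So does the question of whether a change elsewhere on the shared core would move the number.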